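Swapping a Butyl Chain for a Cyclopentyl Ring

This account rests on a few compounds, and the source may have more. Where it says the series, first, only, none or still open, it means among the compounds named here.

Measured compounds:
compound 1, `CCCCn1cnc2c(Nc3cccc(Cl)c3)nc(NCOCc3ccc(/C=C/C(=O)Nc4ccccc4N)cc3)nc21`, gives 4.76%
compound 2, `Nc1ccccc1NC(=O)/C=C/c1ccc(COCNc2nc(Nc3cccc(Cl)c3)c3ncn(C4CCCC4)c3n2)cc1`, gives 9.04%
compound 3, `CCCCn1cnc2c(Nc3ccccc3)nc(NCOCc3ccc(/C=C/C(=O)Nc4ccccc4N)cc3)nc21`, gives 6.58%

All three measured compounds were tested in a functional assay on HCT-116 cells (Homo sapiens) for antiproliferative activity, read by CCK-8 assay, with a stated time of 72 h, tested at 2 uM (on this read-out lower numbers stand for a weaker effect and higher numbers for a stronger effect at the one concentration tested), and all three show small effects. Compound 1 and compound 2 share a core and differ in one place: cyclopentyl in place of butyl on an aromatic nitrogen. The step they make in this assay is a number 4.3 percentage points higher from compound 1 to compound 2 (within the scatter). Compound 1 and compound 3 differ in another place, which is also how the two cores of this comparison differ: hydrogen in place of chloro on an aromatic carbon. That step is a number 1.8 percentage points higher from compound 1 to compound 3 (within the scatter). Compound 2 and compound 3 are not compared directly here; their two values lie within the usual scatter of each other.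

Compound 4, `Nc1ccccc1NC(=O)/C=C/c1ccc(COCNc2nc(Nc3ccccc3)c3ncn(C4CCCC4)c3n2)cc1`, has not yet been measured. It differs from compound 3 in the same way that compound 2 differs from compound 1: cyclopentyl in place of butyl on an aromatic nitrogen. The surroundings of the change are described in the same words in both pairs, so this is the same change, made on a core that differs only as described above.

Going by the values given here, with only one earlier example of this change, and with all three measured values close together, the expectation for compound 4 is modest. The step from compound 3 to compound 4 in this assay is expected to be a number 3.4 percentage points higher from compound 3 to compound 4 (within the scatter), beside the earlier one of a number 4.3 percentage points higher from compound 1 to compound 2 (within the scatter), because the earlier step of a number 4.3 percentage points higher from compound 1 to compound 2 (within the scatter) was small and within the scatter. Compound 4 is estimated at 10%, with a likely range from 2% to 20%.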

Compound 4, a percentage reported as inhibition, at one concentration (the size of the read-out at that concentration, not a potency): 10.5%
The estimate for compound 4 lay 0.5 percentage points below the measured number; the measured number falls inside the stated range.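

In this assay, cyclopentyl in place of butyl on an aromatic nitrogen gives a number 3.9 percentage points higher from compound 3 to compound 4 (within the scatter), and this step matches the one seen earlier on the chloro-bearing core: the same change on two cores in this assay, a number 4.3 percentage points higher (within the scatter) from compound 1 to compound 2 and a number 3.9 percentage points higher (within the scatter) from compound 3 to compound 4, 0.4 percentage points apart, within the scatter of two such steps Hydrogen in place of chloro on an aromatic carbon gives a number 1.5 percentage points higher from compound 2 to compound 4 (within the scatter), and this step likewise matches its earlier counterpart: the same change on two cores in this assay, a number 1.8 percentage points higher (within the scatter) from compound 1 to compound 3 and a number 1.5 percentage points higher (within the scatter) from compound 2 to compound 4, 0.4 percentage points apart, within the scatter of two such steps Each change therefore gave a similar reading on both cores, but every one of these steps lies within the scatter, so the data do not show that either change truly alters the effect, and they say nothing about cores beyond these.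

The compounds shown leave open whether another group on that aromatic nitrogen, such as a longer chain or a cyclohexyl ring, or another group in place of chloro, such as fluoro or methoxy, would give a step beyond the scatter. With all four compounds showing small effects at a single concentration, they also leave open how any of these compounds would behave at other concentrations.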